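This account rests on a few compounds, and the source may have more. Where it says the series, first, only, none or still open, it means among the compounds named here.

Compound 3 `CCC(C)(C)Cc1c[nH]c(CCc2ccc(-c3cccnc3)cc2)n1` gives 131 nM in a functional assay on HEK293 cells for agonist activity at Bombesin receptor subtype-3 (Homo sapiens), read by luminescence and calcium flux, with a stated time of 10 min (a lower number here means that less compound is needed, a higher number that more compound is needed for the effect), the second highest of the three numbers measured. For the measured compounds named here, compound 1 `CCC(C)(C)Cc1c[nH]c(CCc2ccc(-c3cccc(N)n3)cc2)n1` gives 37 nM, and compound 2 `c1ccc(-c2ccc(CCc3nc(CC4CCCC4)c[nH]3)cc2)nc1`, which carries a different substituent on the shared core, gives 425 nM; compound 2 thus sits at the higher end and compound 1 at the lower end of the series so far.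

The change to compound 4 `CCC(C)(C)Cc1c[nH]c(CCc2ccc(-c3cccc(C#N)n3)cc2)n1` is 6-cyanopyridin-2-yl in place of pyridin-3-yl on an aromatic carbon. Going by the values given here, one measured step bears on it: a 3.5-fold higher number from compound 1 to compound 3 (0.55 log units; beyond the scatter), which shows that a pyridin-2-yl carrying a group in its 6-position gave a clearly lower number than plain pyridin-3-yl. Compound 4 returns to a pyridin-2-yl bearing a 6-substituent, now a nitrile rather than an amine. Because compound 1 gave 37 nM with the aminated pyridin-2-yl, a move back toward that arrangement is expected to lower the number, though the nitrile is a different substituent and the size of the effect is uncertain. Compound 4 is therefore expected to show a modest step, a 2.2-fold lower number from compound 3 to compound 4 (0.34 log units; beyond the scatter), in the direction of less compound needed. The estimate for compound 4 is 60 nM, with a range from 20 nM to 200 nM.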

Compound 4, half-maximal effective concentration: 193 nM
Compound 4: middle estimate off by 3.2-fold (0.51 log units), on the low side; the range from low to high includes it.
By their numbers in this assay, from the lowest: compound 1; then compounds 3 and 4 (each within the scatter of the next); then compound 2.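

The exchange of pyridin-3-yl for 6-cyanopyridin-2-yl is a 1.5-fold higher number from compound 3 to compound 4 (0.17 log units; within the scatter), so in this assay these two groups cannot be told apart, even though the new group carries a nitrile that pyridin-3-yl lacks. The earlier compounds could not compare two substituents on the same 6-substituted pyridin-2-yl, and here cyano in place of amino is a 5.2-fold higher number from compound 1 to compound 4 (0.72 log units; beyond the scatter), so having a group at that position of a pyridin-2-yl is not enough for the lower number; among these compounds, that number stays with the amino group of compound 1 alone. Nothing available here explains why the amine and the nitrile part ways.

The compounds shown leave open where a plain pyridin-2-yl with no 6-substituent would fall, and so whether the amine lowers the number from that baseline or the nitrile raises it. They also leave open whether a methyl, a hydroxyl or a methylamino group in that place would side with compound 1 or with compounds 3 and 4, and whether the amino group would bring a similar step on the different substituent of compound 2.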